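Series notes: the step from compound 3 to compound 4

The compounds below may be only part of what the source reports. "The series", "measured", "known", "first", "only" and "open" are said of these compounds alone.

Compound 3 `CC(C)(C)c1ccc(CO/N=C/c2c(-c3ccc4ccccc4c3)nc3occn23)cc1` stands highest of the three measured numbers in an assay on HepG2 cells for agonist activity at nuclear receptor subfamily 1 group I member 3 (Homo sapiens), read by a luciferase reporter, with a stated time of 23 h (on this read-out higher numbers stand for an effect only at larger amounts of compound and lower numbers for an effect already at smaller amounts), giving 7900 nM. Compound 1 `Clc1ccccc1CO/N=C/c1c(-c2ccc3ccccc3c2)nc2occn12` gives 1100 nM and compound 2 `Fc1c(F)c(F)c(CO/N=C/c2c(-c3ccc4ccccc4c3)nc3occn23)c(F)c1F` gives 1700 nM; the step of a 1.5-fold higher number from compound 1 to compound 2 (0.19 log units; within the scatter) is within the scatter, so these two are not ordered against each other. Against compound 3 the steps are larger: a 7.2-fold higher number from compound 1 to compound 3 (0.86 log units; beyond the scatter) and a 4.6-fold higher number from compound 2 to compound 3 (0.67 log units; beyond the scatter).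

Compound 4 `Clc1ccc(CO/N=C/c2c(-c3ccc4ccccc4c3)nc3occn23)cc1` differs from compound 3 by chloro in place of tert-butyl on an aromatic carbon, on the ring carbon para to a large group; one bond further out the change reads 4-(tert-butyl)phenyl to 4-chlorophenyl. Among the compounds with values here, no measured pair carries exactly this change. Within the data shown here, the steps that bear on it are a 7.2-fold higher number from compound 1 to compound 3 (0.86 log units; beyond the scatter) and a 4.6-fold higher number from compound 2 to compound 3 (0.67 log units; beyond the scatter), both ending at compound 3 with the higher number and both modest. Replacing tert-butyl with chloro is therefore expected to lower the number in this assay by a modest margin, estimated at a 3.6-fold lower number from compound 3 to compound 4 (0.56 log units; beyond the scatter). Compound 4 is thus expected to land nearer compound 1 and compound 2 than compound 3. The estimate for compound 4 in this assay is 2200 nM, with a range from 800 nM to 6000 nM.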

Compound 4, half-maximal effective concentration: 990 nM
Beside the measured number, compound 4's estimate is 2.2-fold (0.35 log units) above it; the measured number falls inside the stated range.
By their numbers in this assay, from the lowest: compounds 4, 1 and 2 (each within the scatter of the next); then compound 3.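

In this assay, within the data shown here, the change at the ring carbon para to a large group now stands as a direct step, with an 8.0-fold lower number from compound 3 to compound 4 (0.90 log units; beyond the scatter) for chloro in place of tert-butyl, whereas the earlier steps to compound 3 also changed the rest of the benzyl-side ring. Compound 4 does not separate from the other two, since a 1.7-fold lower number from compound 2 to compound 4 (0.23 log units; within the scatter) and a 1.1-fold lower number from compound 1 to compound 4 (0.05 log units; within the scatter) are both within the scatter, so among these four compounds only the 4-(tert-butyl)phenyl group stands apart, and 2-chlorophenyl and 4-chlorophenyl are not ordered against each other. Nothing available accounts for the step from tert-butyl to chloro.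

As far as these compounds go, whether an amine, a carboxylic acid or a methoxy group at this place stays with compound 4 or moves toward compound 3 remains open. Also open, from the compounds shown here alone, is whether the tert-butyl to chloro step holds on a changed core.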